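Solubility notes on a phenoxy-bearing aminoquinoline series

This account rests on a few compounds, and the source may have more. Where it says the series, first, only, none or still open, it means among the compounds named here.

Measured compounds in a physicochemical assay for solubility, with a stated time of 18 h, at pH 7.4; a higher number here means a more soluble compound, a lower number a less soluble compound:
compound 1, `COc1cccc(CNCCCNc2ccnc3cc(Oc4ccccc4)ccc23)c1O`, gives 14500 nM
compound 2, `COc1cccc(CNCCCNc2ccnc3cc(C4CCCCC4)ccc23)c1O`, gives 4200 nM
compound 3, `COc1cccc(CNCCCNc2ccnc3cc(Cc4ccc(F)cc4)ccc23)c1O`, gives 4200 nM

Compound 1 holds the highest of the three numbers; compound 2 sits a 3.5-fold lower number from compound 1 to compound 2 (0.54 log units; beyond the scatter) and compound 3 sits a 3.5-fold lower number from compound 1 to compound 3 (0.54 log units; beyond the scatter), while between compound 2 and compound 3 there is no change at the digits printed from compound 2 to compound 3 (within the scatter).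

Compound 4, `c1ccc(Oc2ccc3c(NCCCNCc4ccco4)ccnc3c2)cc1`, is not yet measured. It differs from compound 1 at the other end of the chain: furan-2-yl in place of 2-hydroxy-3-methoxyphenyl on a saturated chain carbon bound to an amine nitrogen. All three measured steps change the group on the aromatic carbon of the shared core and leave the 2-hydroxy-3-methoxybenzyl end untouched, so none of them bears directly on this change; the two modest steps from compound 1 only show that this core tolerates changes of around that size without leaving the measurable range. Among the measured compounds shown here, with no guiding step, the expectation for compound 4 is a number close to that of compound 1, with the step of a 1.6-fold lower number from compound 1 to compound 4 (0.21 log units; within the scatter) carrying a wide range either way. The estimated value for compound 4 in this assay is 9000 nM, within 2500 nM to 30000 nM.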

Compound 4, solubility: 14500 nM
Compound 4: middle estimate off by 1.6-fold (0.21 log units), on the low side; measured number inside the range.
By their numbers in this assay, from the lowest: compounds 2 and 3 (each within the scatter of the next); then compounds 1 and 4 (each within the scatter of the next).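

In this assay the exchange of 2-hydroxy-3-methoxybenzyl for (furan-2-yl)methyl reads no change at the digits printed from compound 1 to compound 4 (within the scatter) and gives the first view of the far end of the chain, as all earlier steps sit on the aromatic carbon of the shared core. With phenoxy on the core, furan-2-yl has 5 heavy atoms and 0 hydrogen-bond donors against 9 and 1 for 2-hydroxy-3-methoxyphenyl, and these differences come with no readable shift in this pair. No measurement bearing on either group accompanies this result, so the pair offers no explanation.

Going by these compounds, whether this holds with cyclohexyl or 4-fluorobenzyl on the core stays open, as furan-2-yl appears here only with phenoxy. Also open, on these data alone, is how a piperidine or a carboxylic acid at this end of the chain would read in this assay and whether a longer chain would alter the picture.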